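A Heteroaryl Swap on the Same Ketone Carbon

The source may hold more compounds than are shown below. What is called first, only, known or untested is meant among the compounds shown, and "the series" means these compounds.

Compound 1 `CCCCCCCC/C=C\CCCCCCC(=O)c1ncc(-c2ccco2)o1`: 54 nM
Compound 2 `CCCCCCCCCCCCCCCCCC(=O)C(F)(F)F`: 240 nM
Compound 3 `CCCCCCCC/C=C\CCCCCCC(=O)c1nnn(C)n1`: 65 nM

Of the compounds shown here, three have been tested in an assay on isolated protein for inhibition of Fatty-acid amide hydrolase 1 (Homo sapiens); on this read-out lower numbers stand for stronger inhibition and higher numbers for weaker inhibition. Compound 3 stands second highest of the three numbers. Its nearest neighbour is compound 1, whose number is lower by a margin that lies within the scatter, so the two cannot be ordered on these data. Compound 2 is the furthest away, with a number beyond the scatter higher than that of compound 3.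

Compound 4 `CCCCCCCC/C=C\CCCCCCC(=O)c1nc2ccccc2o1` has not yet been measured. It differs from compound 3 in one place: 1,3-benzoxazol-2-yl in place of 2-methyl-2H-tetrazol-5-yl on a carbonyl carbon. Among the compounds with values here, no step between two measured compounds of this kind has been recorded, so the size of the change can only be expected, not read off. Because compound 3 already gives 65 nM in this assay, a result in the same region or somewhat lower is expected for compound 4, with a chance that the step falls beyond the scatter toward stronger inhibition. The step from compound 3 to compound 4 is estimated as a 3.3-fold lower number from compound 3 to compound 4 (0.51 log units; beyond the scatter). For compound 4 the expected value is 20 nM, with a range from 5 nM to 80 nM.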

Compound 4, inhibition constant: 370 nM
The estimate for compound 4 lay 19-fold (1.27 log units) below the measured number; the whole stated range lies below it.
By their numbers in this assay, from the lowest: compounds 1 and 3 (each within the scatter of the next); then compounds 2 and 4 (each within the scatter of the next).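

In this assay, the carbonyl carbon whose other neighbour is a saturated chain carbon proved sensitive to which aromatic group it carries: putting 1,3-benzoxazol-2-yl in place of 2-methyl-2H-tetrazol-5-yl gave a 5.7-fold higher number from compound 3 to compound 4 (0.76 log units; beyond the scatter), a step toward weaker inhibition. Compound 1 and compound 3 lie within the scatter of each other despite carrying different groups on this carbon, but the new step shows that an aromatic group with hetero atoms at this place does not by itself keep the number in their region. Nothing available bears on the reason for this step.

The compounds shown leave open whether the higher number goes with the added six-membered aromatic ring of carbon only or with the change in hetero atoms in the five-membered ring. An unsubstituted 1,3-oxazol-2-yl or a 1,3-benzothiazol-2-yl on the same carbonyl carbon, with the chain kept as it is, would help to separate these two changes.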